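From methyl to chloro in a toxicity read-out

This account rests on a few compounds, and the source may have more. Where it says the series, first, only, none or still open, it means among the compounds named here.

Measured in a toxicity assay on THP-1 cells (Homo sapiens) for inhibition (on this read-out higher numbers stand for lower toxicity in this test and lower numbers for higher toxicity in this test), so far:
Compound 1 `Cn1c(-c2ccccc2F)cnc1NC(=O)c1ccc(F)cc1` gives > 100000 nM as a limit of the assay
Compound 2 `COc1cccc(-c2cnc(NC(=O)c3ccc(F)cc3)n2C)c1` gives > 100000 nM as a limit of the assay
Compound 3 `Cc1ccc(-c2cnc(NC(=O)c3ccc(F)cc3)n2C)cc1` gives 60000 nM

Among the compounds with values here, compound 3 holds the only actual number in this assay and the other two compounds stand at a limit. That is the limit of > 100000 nM in this assay, at which 2 of the 3 values shown sit.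

Compound 4 `Cn1c(-c2ccc(Cl)cc2)cnc1NC(=O)c1ccc(F)cc1` differs from compound 3 by chloro in place of methyl on an aromatic carbon with chloro in place of methyl on an aromatic carbon para to a large group.

Within the data shown here, two measured steps bear on this place. They are an at least 1.6-fold lower number from compound 1 to compound 3 (0.22 log units; that floor lies within the scatter) and an at least 1.6-fold lower number from compound 2 to compound 3 (0.22 log units; that floor lies within the scatter). Each gives only a floor, and a step that the two limits leave unreadable from compound 1 to compound 2 adds no size. Neither of the first two exchanges methyl for chloro, so no step beyond the scatter is expected in this assay and neither direction is favoured.

The estimate is a 1.1-fold lower number from compound 3 to compound 4 (0.04 log units; within the scatter) as the expected step. A report at the limit remains possible. For compound 4 the expected value is 55000 nM with an estimated range from 25000 nM to 100000 nM.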

Compound 4, half-maximal cytotoxic concentration: 37000 nM
Beside the measured number, compound 4's estimate is 1.5-fold (0.17 log units) above it; the range from low to high includes it.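

In this assay, chloro in place of methyl on this aromatic carbon, para to a large group, gives a 1.6-fold lower number from compound 3 to compound 4 (0.21 log units; within the scatter) and so does not separate the 4-chlorophenyl compound from the 4-methylphenyl compound. Unlike the floors reached by compound 3, those reached by compound 4 lie beyond the scatter: there is an at least 2.7-fold lower number from compound 2 to compound 4 (0.43 log units; beyond the scatter) and also an at least 2.7-fold lower number from compound 1 to compound 4 (0.43 log units; beyond the scatter) in this series. These two steps give floors and not full sizes because compound 1 and compound 2 each stand at an assay limit: the limit of > 100000 nM in this assay, at which 2 of the 4 values shown sit.

The compounds shown leave open how far the true values of compound 1 and compound 2 lie from that of compound 4. They also leave open whether an amine or a carboxylic acid at this place would give a step beyond the scatter from compound 3.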